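Adding a Bromo Group to an Inactive Compound

The source may hold more compounds than are shown below. What is called first, only, known or untested is meant among the compounds shown, and "the series" means these compounds.

Compound 1 (`O=C1Nc2c(F)cccc2/C1=C1/Nc2ccccc2C1=O`) and compound 2 (`O=C1Nc2ccccc2/C1=C1/Cc2ccccc2C1=O`) have both been tested in a functional assay on PC-3 cells (Homo sapiens) for antiproliferative activity, read by MTT assay, with a stated time of 72 h; a higher number here means a weaker inhibitor, a lower number a stronger inhibitor. In this assay compound 1 gives > 100000 nM, which is a limit of the assay and not a number. Compound 2 gives > 100000 nM, which is also only a limit. The whole record so far is therefore (the limit of > 100000 nM in this assay, at which 2 of the 2 values shown sit), and no actual potency can be read for compound 2.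

Compound 3 (`O=C1Nc2ccc(Br)cc2/C1=C1/Cc2ccccc2C1=O`) keeps the core of compound 2 and differs in one place: bromo in place of hydrogen on an aromatic carbon. This puts bromo in place of hydrogen on an aromatic carbon. Going by the values given here, no measured pair of compounds shows what a single change does here, so any forecast is loose. In this assay a modest shift toward stronger inhibition is expected, and the result may well stay at the limit. The expected change is an at least 1.6-fold lower number from compound 2 to compound 3 (0.22 log units; that floor lies within the scatter), an estimate that starts from a limit. Compound 3 is estimated at 60000 nM, with an expected range of 15000 nM to 100000 nM.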

Compound 3, half-maximal inhibitory concentration: > 100000 nM
Compound 3: only a limit was reported (the forecaster's own chance of this, stated with the estimate: 55%); middle value at least 1.6-fold (0.22 log units) from the limit.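

In this assay compound 3 gives > 100000 nM, which is a limit of the assay and not a number. Compound 2 also stands at a limit, so no step can be read between compound 2 and compound 3. The compounds shown leave open what bromo in place of hydrogen does to actual potency, as all of them share one limit: the limit of > 100000 nM in this assay, at which 3 of the 3 values shown sit.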